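Notes on the series: from compound 2 to compound 3

The source may report more compounds than this note shows. Statements on the series, on what has been measured and on what is new or still open speak of the compounds shown alone.

Measured in a functional assay on DU-145 cells (Homo sapiens) for inhibition, read by trypan blue exclusion, with a stated time of 96 h; on this read-out lower numbers stand for stronger inhibition of growth and higher numbers for weaker inhibition of growth:
- compound 1 `Cc1ccc(CS(=O)(=O)/C(=C/c2ccc(Br)cc2)C(=O)c2ccc(Cl)cc2)cc1`: 25000 nM
- compound 2 `Cc1ccc(CS(=O)(=O)/C(=C/c2cc(C)cc(C)c2)C(=O)c2ccc(Cl)cc2)cc1`: 10000 nM

Compound 2 holds the lower of the two numbers. Compound 3 `Cc1ccc(CS(=O)(=O)/C(=C/c2cccc(Cl)c2Cl)C(=O)c2ccc(Cl)cc2)cc1` puts 2,3-dichlorophenyl in place of 3,5-dimethylphenyl on a double-bonded chain carbon bound to a double-bonded chain carbon. Within the data shown here, one measured step bears on this place, a 2.5-fold lower number from compound 1 to compound 2 (0.40 log units; beyond the scatter), and it is modest. Among the measured compounds shown here, with only this step as a guide, and with compound 1 at 25000 nM also carrying a halogenated ring there, a small rise is expected in this assay. The expected step is a 1.4-fold higher number from compound 2 to compound 3 (0.15 log units; within the scatter). For compound 3 the estimated value is 14000 nM, with an expected range of 5000 nM to 35000 nM.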

Compound 3, concentration for 50% growth inhibition: 1000 nM
Estimate against measurement, compound 3: 14-fold (1.15 log units) above; the measured number lies below the stated range.
By their numbers in this assay, from the lowest: compound 3; then compound 2; then compound 1.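

On a double-bonded chain carbon bound to a double-bonded chain carbon, the choice of aryl group moves the result in this assay over a wide span, with a 10-fold lower number from compound 2 to compound 3 (1.00 log units; beyond the scatter) and a 25-fold lower number from compound 1 to compound 3 (1.40 log units; beyond the scatter). Halogen on this ring does not by itself weaken growth inhibition, as the halogenated compound 3 and compound 1 hold the two ends of the three numbers. No measurement at hand accounts for this gain.

As far as these compounds go, whether the gain needs both chlorines of 2,3-dichlorophenyl remains open. So does the outcome with an amine or a carboxylic acid on this ring.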